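Methyl on the pyridine amide: a step into the unknown

The source may hold more compounds than are shown below. What is called first, only, known or untested is meant among the compounds shown, and "the series" means these compounds.

compound 1 `C=CC(=O)Nc1cccc(Nc2ncnc(Nc3ccc(Oc4ccc(OC)cc4)cc3)n2)c1` — > 100000 nM
compound 2 `C=CC(=O)Nc1cccc(Nc2ncnc(Nc3ccc(C(=O)Nc4ccccn4)cc3)n2)c1` — "not determined" (no result reported)
compound 3 `CC#CC(=O)Nc1cccc(Nc2ncnc(Nc3ccc(C(=O)N4CCCCC4)cc3)n2)c1` — 24400 nM

In a functional assay on Ramos cells (Homo sapiens) for antiproliferative activity, read by CCK-8 assay, with a stated time of 24 h (on this read-out higher numbers stand for weaker inhibition and lower numbers for stronger inhibition), compound 1 gives > 100000 nM, which is a limit of the assay and not a number, the point described by the limit of > 100000 nM in this assay, at which 1 of the 3 values shown sits. Compound 3 gives 24400 nM in this assay. Compound 2 gives "not determined" (no result reported): no number is reported for it, so it stands nowhere on the scale that compound 1 and compound 3 set. Compound 4 `C=CC(=O)Nc1cccc(Nc2ncnc(Nc3ccc(C(=O)Nc4ccc(C)cn4)cc3)n2)c1` differs from compound 2 by methyl in place of hydrogen on an aromatic carbon. For the measured compounds named here, no measured pair shows such a step here, and in this assay a change no larger than the usual scatter, in either direction, is expected. Compound 4 is therefore expected to give an estimated 30000 nM, with a range from 5000 nM to 150000 nM.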

Compound 4, half-maximal inhibitory concentration: > 100000 nM
Compound 4 ended at the assay's limit (the forecaster's own chance of this, stated with the estimate: 40%); middle value at least 3.3-fold (0.52 log units) from the limit.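

Compound 4 gives > 100000 nM, a limit of the assay and not a number. No step can be read from compound 1, also at a limit, or from compound 2, which has no number. The compounds shown leave open whether (5-methylpyridin-2-yl)carbamoyl and (pyridin-2-yl)carbamoyl differ in activity at all.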